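Replacing chloro with hydroxy on a weakly cytotoxic compound

A few compounds are considered here, and "the series" means these few. Any claim that something is new, unique, unknown or untested is made for them only; others in the source may bear on it.

Measured in a functional assay on HT29-AK cells (Homo sapiens) for cytotoxicity, read by MTT assay, with a stated time of 48 h; on this read-out lower numbers stand for stronger inhibition and higher numbers for weaker inhibition:
Compound 1 `Fc1cccc(-c2nc(Nc3ccccc3)c3ccccc3n2)c1`: > 50000 nM (a limit of the assay)
Compound 2 `Fc1cccc(Nc2nc(-c3cccc(F)c3)nc3ccc(F)cc23)c1`: > 50000 nM (a limit of the assay)
Compound 3 `Fc1cccc(-c2nc(Nc3ccc(Cl)cc3)c3cc(F)ccc3n2)c1`: 40300 nM

Compound 3 is the only one of the three with an actual number in this assay, since the other two values are limits. Compound 4 `Oc1ccc(Nc2nc(-c3cccc(F)c3)nc3ccc(F)cc23)cc1` has not yet been measured. It differs from compound 3 as follows: hydroxy in place of chloro on an aromatic carbon. In short, hydroxy takes the place of chloro on an aromatic carbon, para to a large group.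

Among the compounds with values here, only one measured step touches the same group on the nitrogen. That step, an at least 1.2-fold lower number from compound 2 to compound 3 (0.09 log units; that floor lies within the scatter), gives no firm size and no firm direction. Within the data shown here, no measured compound carries hydroxy, so the data offer no direct guide to this exchange. Also relevant is the limit of > 50000 nM in this assay, at which 2 of the 3 values shown sit, which shows how readily this series reaches the end of the measurable range.

No shift beyond the usual scatter is therefore expected, and a reading at the limit would not be surprising. The expected change is a 1.3-fold lower number from compound 3 to compound 4 (0.13 log units; within the scatter). The estimated value for compound 4 is 30000 nM, with an expected range from 8000 nM to 50000 nM.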

Compound 4, half-maximal inhibitory concentration: > 50000 nM
Compound 4: a limit, no number; the forecaster's own chance of this, stated with the estimate: 35%; middle value at least 1.6-fold (0.22 log units) away from the limit.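

In this assay compound 4 gives > 50000 nM, which is a limit of the assay and not a number. The exchange of chloro for hydroxy at this place on the ring comes out as an at least 1.2-fold higher number from compound 3 to compound 4 (0.09 log units; that floor lies within the scatter), so the earlier hint from the 4-chlorophenyl compound gains no firm size or direction, though hydroxy at this place, with its hydrogen-bond donor, does not yield a reading inside the measurable range. The step that links the 4-hydroxyphenyl compound to the 3-fluorophenyl compound cannot be read, and the series now sits even more firmly at the end of the range, which limits what this position can reveal here: the limit of > 50000 nM in this assay, at which 3 of the 4 values shown sit.

With compound 3 at 40300 nM as the only actual number, the compounds shown leave open whether anything at this place on the ring can move the value clearly beyond the usual scatter. As far as these compounds go, whether an amine, a methoxy group or a carboxylic acid in the same place would give a reading, and how it would compare with chloro, remains open.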